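The source may report more compounds than this note shows. Statements on the series, on what has been measured and on what is new or still open speak of the compounds shown alone.

Measured so far:
compound 1, `Cc1c(C#N)c(Nc2ccc(S(N)(=O)=O)cc2)nc2nc(NCCO)nc(N)c12`: 38200 nM
compound 2, `Cc1c(C#N)c(NCCO)nc2nc(NCCO)nc(N)c12`: 20100 nM

In a functional assay on SNU-638 cells (Homo sapiens) for inhibition, read by sulforhodamine B assay, with a stated time of 2 days (a lower number here means a stronger inhibitor of growth, a higher number a weaker inhibitor of growth), compound 1 gives 38200 nM and compound 2 gives 20100 nM. Compound 1 shows the higher of the two numbers, yet its gap to compound 2 lies within the scatter of repeated measurements, so the two compounds cannot be told apart on these data. The unmeasured compound 3, `Cc1c(C#N)c(Nc2ccc(S(N)(=O)=O)cc2)nc2ncnc(N)c12`, keeps the shared core of compound 1 and differs from it in one place: hydrogen in place of (2-hydroxyethyl)amino on an aromatic carbon. Among the measured compounds shown here, no pair of measured compounds shows what this change does, so its effect is unknown here. The step in this assay is expected to be modest, with no clear direction, and it may well stay inside the scatter. The expected step is a 1.0-fold higher number from compound 1 to compound 3 (0.02 log units; within the scatter). For compound 3 in this assay the estimate is 40000 nM, with a range from 10000 nM to 150000 nM.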

Compound 3, concentration for 50% growth inhibition: 16600 nM
For compound 3 the middle estimate is 2.4-fold (0.38 log units) above the measured one; the range from low to high includes it.
By their numbers in this assay, from the lowest: compounds 3, 2 and 1 (each within the scatter of the next, the first and the last beyond it).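

In this assay, among the compounds shown here, putting hydrogen in place of (2-hydroxyethyl)amino on the aromatic carbon between two ring nitrogen atoms gives a 2.3-fold lower number from compound 1 to compound 3 (0.36 log units; beyond the scatter), a first direct reading of a change at this position. The number moves towards stronger growth inhibition, so on the shared core of compound 1 this group is not required for the activity seen in this assay, and its removal brings a modest gain rather than a loss. No measurement shown here accounts for the step.

Going by these compounds, it remains open whether another group on this carbon, such as a methyl group or a longer chain ending in a carboxylic acid, would lower the number further or raise it. On these data alone, it is equally open whether hydrogen at this carbon would have a similar effect on compound 2 , which carries a different group elsewhere on the core.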